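From tert-butyl to methylsulfanyl on the shared core

The source may report more compounds than this note shows. Statements on the series, on what has been measured and on what is new or still open speak of the compounds shown alone.

Compound 1 (`Cc1cc(NC(=O)Nc2ccccc2N)c2ccccc2n1`) gives > 25000 nM as a limit
Compound 2 (`Cc1cc(NC(=O)Nc2ccccc2C(C)(C)C)c2ccccc2n1`) gives > 25000 nM as a limit

Both results come from an ADME assay on HepG2 cells (Homo sapiens) for cytotoxicity, with a stated time of 72 h (on this read-out lower numbers stand for an effect already at smaller amounts and higher numbers for an effect only at larger amounts of compound), and neither is a number. Compound 2 therefore stands only at the limit > 25000 nM and offers no exact starting point. Compound 3 (`CSc1ccccc1NC(=O)Nc1cc(C)nc2ccccc12`) has methylsulfanyl in place of tert-butyl on an aromatic carbon and is otherwise the same. Among the compounds with values here, the only measured step at this place is a step that the two limits leave unreadable from compound 1 to compound 2 and it gives no usable size. The evidence is the limit of > 25000 nM in this assay, at which 2 of the 2 values shown sit, and from it no step beyond the scatter is expected in this assay in either direction. The estimate means a step that the limit leaves unreadable from compound 2 to compound 3 as the expected step. For compound 3 the estimated value is 30000 nM with an expected range from 12000 nM to 60000 nM and another result given only as a limit is likely.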

Compound 3, half-maximal effective concentration: > 25000 nM
Compound 3: no number, only a limit; the forecaster's own chance of this, stated with the estimate: 85%; the middle value lies beyond the limit too.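

In this assay compound 3 gives > 25000 nM, which is a limit and not a number. Within the data shown here, no step among compound 1, compound 2 and compound 3 can be read. The compounds shown leave open whether these three differ at all on this read-out, and how large any such difference would be.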